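Chloro Replaced by Benzyloxy: What to Expect for Compound 4

A few compounds are considered here, and "the series" means these few. Any claim that something is new, unique, unknown or untested is made for them only; others in the source may bear on it.

Compound 1, `COCc1cn(-c2ccccc2)[nH]c1=O`: in an assay on isolated protein for inhibition of Polyunsaturated fatty acid 5-lipoxygenase (Rattus norvegicus) (a higher number here means a weaker inhibitor, a lower number a stronger inhibitor), compound 1 gives > 1000 nM, which is a limit of the assay rather than a number.
Compound 2, `COCCC1CN(c2ccc(Cl)c(Cl)c2)NC1=O`: compound 2 gives 190 nM.
Compound 3, `COCCC1CN(c2ccc(Cl)cc2)NC1=O`: compound 3 gives 250 nM.

Compound 3 sits at the higher of the two numbers shown, and its nearest neighbour is compound 2; the step of a 1.3-fold higher number from compound 2 to compound 3 (0.12 log units; within the scatter) lies within the scatter, so the two are not distinguished. Compound 1 has a different core and contributes only (the limit of > 1000 nM in this assay, at which 1 of the 3 values shown sits).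

Compound 4, `COCCC1CN(c2ccc(OCc3ccccc3)cc2)NC1=O`, differs from compound 3 by benzyloxy in place of chloro on an aromatic carbon. Going by the values given here, the only measured step on this ring, a 1.3-fold higher number from compound 2 to compound 3 (0.12 log units; within the scatter), concerns a chloro leaving and changed little; nothing measured here involves a benzyloxy entering, so the direction of this larger change is open. Compound 4 is expected to move by a 1.6-fold lower number from compound 3 to compound 4 (0.19 log units; within the scatter). Compound 4 is estimated at 160 nM, with a range from 40 nM to 650 nM.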

Compound 4, half-maximal inhibitory concentration in the Polyunsaturated fatty acid 5-lipoxygenase assay: 500 nM
Compound 4: middle estimate off by 3.1-fold (0.49 log units), on the low side; the range from low to high includes it.
By their numbers in the Polyunsaturated fatty acid 5-lipoxygenase assay, from the lowest: compounds 2, 3 and 4 (each within the scatter of the next, the first and the last beyond it). At a limit, above all of these: compound 1.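

In the Polyunsaturated fatty acid 5-lipoxygenase assay the exchange gives a 2.0-fold higher number from compound 3 to compound 4 (0.30 log units; within the scatter), so this place on the aromatic ring accepts benzyloxy, with its eight heavy atoms and added aromatic ring, in place of a single chloro without a change that stands clear of the scatter. Going by these compounds alone, this is the first step here in which a group enters this ring rather than a chloro leaving. In a physicochemical assay for lipophilicity (a higher number here means a more lipophilic compound, a lower number a more polar compound), compound 3 gives 1.24 and compound 4 gives 2.22. In the physicochemical assay the same exchange does stand clear of the scatter, so for this pair lipophilicity changes measurably while inhibition does not: the measured partition coefficient of compound 3, 1.24, and of compound 4, 2.22, a number 0.98 log units higher (beyond the scatter)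

Going by these compounds, whether a methoxy, which keeps the oxygen but lacks the added ring, would read the same remains open. So does the outcome with an amine or a carboxylic acid at this place on the ring.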